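This account rests on a few compounds, and the source may have more. Where it says the series, first, only, none or still open, it means among the compounds named here.

Measured compounds:
- compound 1, `Cc1cc(OCc2cccc(F)c2)ccc1CN[C@@H](C)C(N)=O`: 69 nM
- compound 2, `CC1(C)C[C@@H](C(N)=O)N(Cc2ccc(OCc3cccc(F)c3)cc2)C1`: 1420 nM

Two compounds carry a number in an assay on Sf9 cells for inhibition of Amine oxidase [flavin-containing] B (Homo sapiens), with stated times of 15 min and 60 min; a higher number here means a weaker inhibitor, a lower number a stronger inhibitor. Compound 1 gives 69 nM, the lowest of the two numbers. For the measured compounds named here, compound 2 gives 1420 nM, a number that stands far above that of compound 1, well beyond the scatter of repeated measurements; no single-point step links these two structures, so the two values are only noted side by side.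

The piece now turns to compound 3, `Cc1cc(OCc2cccc(F)c2)ccc1CN1CC[C@H]1C(N)=O`, which is not yet measured. It differs from compound 1 in one place: 2-carbamoylazetidin-1-yl in place of (1-carbamoylethyl)amino on a saturated chain carbon bound to an aromatic carbon. The open (1-carbamoylethyl)amino chain of compound 1 is thus closed into a four-membered ring that holds the same carboxamide and one fewer hydrogen-bond donor.

Going by the values given here, no measured pair shows this change directly. Among the compounds with values here, the only tertiary-amine ring compound with a number, compound 2, stands much weaker than compound 1, but it differs in more than one place, so it gives only a loose hint. Compound 3 is expected to be somewhat weaker than compound 1, with a step of a 4.3-fold higher number from compound 1 to compound 3 (0.64 log units; beyond the scatter) in this assay. The estimate for compound 3 is 300 nM, within a range from 80 nM to 1200 nM.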

Compound 3, half-maximal inhibitory concentration: 258 nM
Compound 3: middle estimate off by 1.2-fold (0.07 log units), on the high side; the range from low to high includes it.
By their numbers in this assay, from the lowest: compound 1; then compound 3; then compound 2.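

Closing the open (1-carbamoylethyl)amino chain into 2-carbamoylazetidin-1-yl on a saturated chain carbon bound to an aromatic carbon gives the first direct reading of a change at this position in this assay, with a 3.7-fold higher number from compound 1 to compound 3 (0.57 log units; beyond the scatter). The change therefore weakens inhibition by a modest step, and the four-membered ring is tolerated at this position, at least on the core of compound 1. The entering group has 1 hydrogen-bond donor against 2 in the group it replaces and also adds a ring, but this single step cannot separate those differences, and no measurement shown here explains the rise in the number.

The compounds shown leave open how the carboxamide contributes to the number in this assay, since a carboxylic acid or a nitrile in its place would be needed to test it. They also leave open whether a larger ring, such as a piperidine carrying the same carboxamide, or the opposite configuration at the defined stereocentre of the four-membered ring would read closer to compound 1.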